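Swapping a Pyrazole for a Pyridine on a Receptor Agonist

This account rests on a few compounds, and the source may have more. Where it says the series, first, only, none or still open, it means among the compounds named here.

Compound 1 `CCC(C)(C)Cc1c[nH]c(CCc2ccc(-n3cccn3)cc2)n1` is the starting point. Within the data shown here, in a functional assay on HEK293 cells for agonist activity at Bombesin receptor subtype-3 (Homo sapiens), read by luminescence and calcium flux, with a stated time of 10 min (a higher number here means that more compound is needed for the effect, a lower number that less compound is needed), compound 1 gives 135 nM, the lowest of the two numbers measured so far. Among the measured compounds shown here, its only measured neighbour, compound 2 `CCC(C)(C)Cc1c[nH]c(CCc2ccc(-n3cncn3)cc2)n1`, gives 570 nM in this assay; that step is a 4.2-fold higher number from compound 1 to compound 2 (0.63 log units; beyond the scatter), so exchanging one five-membered aromatic ring for another already shifted the number beyond the scatter. The new compound 3 `CCC(C)(C)Cc1c[nH]c(CCc2ccc(-c3cccnc3)cc2)n1` differs from compound 1 in one place: pyridin-3-yl in place of 1H-pyrazol-1-yl on an aromatic carbon. For the measured compounds named here, no measured step involves a six-membered aromatic ring, so the only guide is the step from compound 1 to compound 2, in which replacing 1H-pyrazol-1-yl raised the number. A moderately higher number is therefore expected for compound 3, with wide uncertainty. The expected step is a 2.2-fold higher number from compound 1 to compound 3 (0.35 log units; beyond the scatter). Compound 3 is estimated at 300 nM, with a likely range from 80 nM to 1200 nM.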

Compound 3, half-maximal effective concentration: 131 nM
Compound 3: middle estimate off by 2.3-fold (0.36 log units), on the high side; the measured number falls inside the stated range.
By their numbers in this assay, from the lowest: compounds 3 and 1 (each within the scatter of the next); then compound 2.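

At this place, on an aromatic carbon para to a large group, a six-membered aromatic ring serves as well as a five-membered one: the step is a 1.0-fold lower number from compound 1 to compound 3 (0.01 log units; within the scatter) in this assay when pyridin-3-yl replaces 1H-pyrazol-1-yl. A step of a 4.4-fold lower number from compound 2 to compound 3 (0.64 log units; beyond the scatter) shows that the higher number of the 1H-1,2,4-triazol-1-yl compound does not follow from replacing 1H-pyrazol-1-yl as such. Nothing measured here explains why these groups give the numbers they do.

The compounds shown leave open whether the ring nitrogen must be present at all, which a plain phenyl ring would test, and whether its place in the ring matters, which pyridin-2-yl or pyridin-4-yl would test. They also leave open how an amine or a carboxylic acid on this ring would read.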